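A few compounds are considered here, and "the series" means these few. Any claim that something is new, unique, unknown or untested is made for them only; others in the source may bear on it.

Working notes on the series in a functional assay on NCI-H460 cells (Homo sapiens) for antiproliferative activity, read by XTT assay, with a stated time of 72 h; on this read-out higher numbers stand for weaker inhibition and lower numbers for stronger inhibition.

Compound 1 `COc1ccc(-c2cc3ccccc3nc2/C=C/C(=O)c2ccc(F)cc2)cc1` gives 6990 nM in this assay. Compound 3 `COc1ccc(-c2cc3ccccc3nc2/C=C/C(=O)c2c(OC)cccc2OC)cc1` gives 6630 nM. For compound 2 `COc1ccc(C(=O)/C=C/c2nc3ccccc3cc2-c2ccc(OC)cc2)cc1` the assay reports no number but only a limit, > 10000 nM, which is the limit of > 10000 nM in this assay, at which 1 of the 3 values shown sits. Among the two numbers compound 1 stands highest, with compound 3 nearest at a 1.1-fold lower number from compound 1 to compound 3 (0.02 log units; within the scatter), so the two are not distinguishable. The step of an at least 1.4-fold higher number from compound 1 to compound 2 (0.15 log units; that floor lies within the scatter) and the step of an at least 1.5-fold lower number from compound 2 to compound 3 (0.17 log units; that floor lies within the scatter) are each known only as a floor that lies within the scatter.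

The unmeasured compound 4 `COc1ccc(-c2cc3ccccc3nc2/C=C/C(=O)c2cnc(N)nc2C)cc1` differs from compound 1 in one place: 2-amino-4-methylpyrimidin-5-yl in place of 4-fluorophenyl on a carbonyl carbon. The three measured steps all exchange the ring on the carbonyl carbon, and none of them moves the number beyond the scatter. None of them, however, brings in a ring with hetero atoms, a hydrogen-bond donor or an amino group, so the change to compound 4 is not covered by a directly matching step. Resting on the steps seen so far, the expectation for compound 4 is no change beyond the scatter, a 1.0-fold higher number from compound 1 to compound 4 (0.00 log units; within the scatter), with the uncertainty widened because the ring type is new. The estimate for compound 4 is 7000 nM, expected to fall between 2500 nM and 10000 nM.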

Compound 4, half-maximal inhibitory concentration: > 10000 nM
Compound 4 ended at the assay's limit; the forecaster's own chance of this, stated with the estimate: 35%; middle value at least 1.4-fold (0.15 log units) from the limit.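

In this assay compound 4 gives only a limit, > 10000 nM, so the first ring with hetero atoms and an amino group at this position yields no number. The exchange on the carbonyl carbon is known only as two floors, an at least 1.4-fold higher number from compound 1 to compound 4 (0.15 log units; that floor lies within the scatter) and an at least 1.5-fold higher number from compound 3 to compound 4 (0.17 log units; that floor lies within the scatter), so the data show no stronger inhibition with 2-amino-4-methylpyrimidin-5-yl, but they do not establish weaker inhibition beyond the scatter either. The step between compound 2 and compound 4 cannot be read, and two quite different rings on the carbonyl carbon now end at the same ceiling: the limit of > 10000 nM in this assay, at which 2 of the 4 values shown sit.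

On these data alone, how far the true value of compound 4 lies past the limit stays unknown, as does whether the amino group, the methyl group or the ring nitrogens decide the outcome. An unsubstituted pyrimidin-5-yl ring, a pyridin-3-yl ring or a dimethylamino group in place of the amino group on the same carbonyl carbon would be needed to separate these parts, and any such comparison would need values that fall clear of the limit.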